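This account rests on a few compounds, and the source may have more. Where it says the series, first, only, none or still open, it means among the compounds named here.

Compound 1 `CCOC(=O)CN(C)C(=O)c1ccc(C(CC)(CC)c2ccc(OCC(=O)C(C)(C)C)c(C)c2)n1CC` stands at a limit in an assay on HL-60 cells for agonist activity at vitamin D3 receptor (Homo sapiens), read by microscopy, with a stated time of 96 h; a higher number here means that more compound is needed for the effect, a lower number that less compound is needed: compound 1 gives > 50000 nM, a limit of the assay rather than a number (the limit of > 50000 nM in this assay, at which 1 of the 2 values shown sits). Compound 2 `CCN(CC)CCNC(=O)c1ccc(C(CC)(CC)c2ccc(OCC(=O)C(C)(C)C)c(C)c2)n1CC` in this assay gives 91 nM. The measured step of an at least 540-fold lower number from compound 1 to compound 2 (2.73 log units; beyond the scatter) is large. Among the compounds with values here, compound 3 `CCN(CC)CCCNC(=O)c1ccc(C(CC)(CC)c2ccc(OCC(=O)C(C)(C)C)c(C)c2)n1CC` carries (3-(diethylamino)propyl)amino in place of ((ethoxycarbonyl)methyl)(methyl)amino on a carbonyl carbon, a change that parallels the one from compound 1 to compound 2. Within the data shown here, the only step that bears on it, an at least 540-fold lower number from compound 1 to compound 2 (2.73 log units; beyond the scatter), was large, so a large downward step is expected, an at least 330-fold lower number from compound 1 to compound 3 (2.52 log units; beyond the scatter). Compound 3 is estimated in this assay at 150 nM, with an expected range from 30 nM to 800 nM.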

Compound 3, half-maximal effective concentration: 22 nM
The estimate for compound 3 lay 6.8-fold (0.83 log units) above the measured number, outside the stated range (below it).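

In this assay the step from diethylamino to (diethylamino)methyl on the chain gives a 4.1-fold lower number from compound 2 to compound 3 (0.62 log units; beyond the scatter) and shows that the length of this chain on the carbonyl carbon counts, not only the presence of its amine. The full replacement of the ((ethoxycarbonyl)methyl)(methyl)amino group reads as an at least 2200-fold lower number from compound 1 to compound 3 (3.35 log units; beyond the scatter) and is open-ended. The value of compound 1 is a limit and not a number: the limit of > 50000 nM in this assay, at which 1 of the 3 values shown sits. On these data alone, whether the number keeps falling with a still longer chain, or holds with a dimethylamino or pyrrolidine group in place of diethylamino, stays open.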